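From Chloro to Hydroxy on a Shared Core

A few compounds are considered here, and "the series" means these few. Any claim that something is new, unique, unknown or untested is made for them only; others in the source may bear on it.

In a functional assay on NCI-H460 cells (Homo sapiens) for cytotoxicity, read by MTT assay, with a stated time of 48 h (a lower number here means a stronger inhibitor, a higher number a weaker inhibitor), compound 1 (`COc1cc(/C=C/C(=O)/C=C/c2nc3cc(C)ccc3n2C)ccc1O`) gives 7700 nM and compound 2 (`COc1cc(/C=C/C(=O)/C=C/c2nc3cc(Cl)ccc3n2C)ccc1O`) gives 8900 nM so the two sit level with each other. Compound 3 (`COc1cc(/C=C/C(=O)/C=C/c2nc3cc(O)ccc3n2C)ccc1O`) has not yet been measured. It keeps the core of compound 2 but carries hydroxy in place of chloro on an aromatic carbon. Within the data shown here, only one measured step bears on this change, chloro in place of methyl on an aromatic carbon (a 1.2-fold higher number from compound 1 to compound 2 (0.06 log units; within the scatter)), and it lies within the scatter. That step involves no hydroxy group, so it is a limited guide. On this evidence, no step beyond the scatter is expected in this assay for the new group. The expected step is small (a 1.1-fold lower number from compound 2 to compound 3 (0.05 log units; within the scatter)) and stays within the scatter. For compound 3 the expected value is 8000 nM with an estimated range of 3500 nM to 18000 nM for the coming measurement.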

Compound 3, half-maximal inhibitory concentration: 7600 nM
For compound 3 the middle estimate is 1.1-fold (0.02 log units) above the measured one, within the range that was stated.
By their numbers in this assay, from the lowest: compounds 3, 1 and 2 (each within the scatter of the next).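

In this assay, hydroxy in place of chloro is a 1.2-fold lower number from compound 2 to compound 3 (0.07 log units; within the scatter), and hydroxy in place of methyl is a 1.0-fold lower number from compound 1 to compound 3 (0.01 log units; within the scatter). The earlier pair showed only that chloro and methyl sit level, while this result adds that a group with a hydrogen-bond donor and a hydrogen-bond acceptor, which chloro lacks, also sits level with them at this aromatic carbon. No measurement shown here speaks to why the three numbers stay level.

Going by these compounds, whether an amine, a carboxylic acid or a longer chain on this carbon would produce a step beyond the scatter remains open. So does whether hydroxy would behave the same way on a different core, since these three compounds all share one.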